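Acetyl for chloro on compound 2: working note

The source may hold more compounds than are shown below. What is called first, only, known or untested is meant among the compounds shown, and "the series" means these compounds.

Measured so far:
compound 1 `COc1cc(Cn2cc(COc3cccc(/C=C4\C(=O)Nc5ccccc54)c3)nn2)cc(OC)c1` — in a functional assay on A549 cells (Homo sapiens) for inhibition, read by MTT assay, with a stated time of 48 h (on this read-out higher numbers stand for weaker inhibition and lower numbers for stronger inhibition), compound 1 gives 43300 nM.
compound 2 `O=C1Nc2ccc(Cl)cc2/C1=C/c1cccc(OCc2cn(Cc3ccccc3)nn2)c1` — for compound 2 this assay reports only a limit, > 50000 nM.
compound 3 `O=C1Nc2cc(Cl)ccc2/C1=C\c1cccc(OCc2cn(Cc3ccccc3)nn2)c1` — for compound 3 this assay reports only a limit, > 50000 nM.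

Compound 2 stands at the limit of this assay, not at a number, so nothing on the numbers shown separates it from compound 3, and compound 1 is the only member with a measured value. the limit of > 50000 nM in this assay, at which 2 of the 3 values shown sit, is where two of the three values sit, which marks this as a weakly active series.

Compound 4 `CC(=O)c1ccc2c(c1)/C(=C/c1cccc(OCc3cn(Cc4ccccc4)nn3)c1)C(=O)N2` differs from compound 2 by acetyl in place of chloro on an aromatic carbon. For the measured compounds named here, no step between measured compounds in this assay is available, and the only one-place exchange seen, between compound 2 and compound 3, moves from one limit to another. The expected step from compound 2 to compound 4, an at least 1.1-fold lower number from compound 2 to compound 4 (0.04 log units; that floor lies within the scatter), is therefore none beyond the scatter. Compound 4 is estimated at 45000 nM, within 15000 nM to 100000 nM, with a fair chance that this assay again reports only a limit.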

Compound 4, half-maximal inhibitory concentration: 36300 nM
Beside the measured number, compound 4's estimate is 1.2-fold (0.09 log units) above it; the range from low to high includes it.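

In this assay, acetyl in place of chloro on this aromatic carbon gives an at least 1.3-fold lower number from compound 2 to compound 4 (0.13 log units; that floor lies within the scatter). The position therefore accepts a larger group carrying a carbonyl and still yields a measured number for compound 4, whereas compound 2 is reported only as a limit. The true size of the step cannot be read, because its starting point is a limit and not a number: the limit of > 50000 nM in this assay, at which 2 of the 4 values shown sit.

As far as these compounds go, whether an amine, a carboxylic acid or a longer acyl chain on this aromatic carbon would give a step beyond the scatter remains open. Also open, from the compounds shown here alone, is whether acetyl would give a measured number at the position that carries chloro in compound 3, and how either substituted compound compares with the same core bearing only hydrogen there.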